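The compounds below may be only part of what the source reports. "The series", "measured", "known", "first", "only" and "open" are said of these compounds alone.

Compound 1 `O=C(O)CCc1ccncc1-c1ccc2ccccc2c1` gives only the limit of the assay in a functional assay on MDA-MB-231 cells (Homo sapiens) for inhibition, read by sulforhodamine B assay, with a stated time of 72 h (a higher number here means a weaker inhibitor of growth, a lower number a stronger inhibitor of growth), > 10000 nM.
Compound 2 `COC(=O)/C=C/c1ccncc1-c1ccc2ccccc2c1` gives 4710 nM in this assay.
Compound 3 `NNC(=O)CCc1ccncc1-c1ccc2ccccc2c1` gives only the limit of the assay in this assay, > 10000 nM.

Among these three, compound 2 holds the only full number; the other two sit at the limit of > 10000 nM in this assay, at which 2 of the 3 values shown sit. Compound 4 `O=C(/C=C/c1ccncc1-c1ccc2ccccc2c1)N1CCOCC1` has not yet been measured. It differs from compound 2 by morpholin-4-yl in place of methoxy on a carbonyl carbon. Among the compounds with values here, none of the measured steps changes the carbonyl substituent alone while keeping the ethenyl chain: the step of an at least 2.1-fold lower number from compound 1 to compound 2 (0.32 log units; beyond the scatter) and the step of an at least 2.1-fold higher number from compound 2 to compound 3 (0.32 log units; beyond the scatter) each alter the chain and the carbonyl substituent together, and a step that the two limits leave unreadable from compound 1 to compound 3 cannot be read. The measured steps therefore speak only indirectly to this change. Since compound 4 keeps the ethenyl chain that sets compound 2 apart from compounds 1 and 3, compound 4 is expected to stay close to compound 2, with a step of a 1.1-fold higher number from compound 2 to compound 4 (0.03 log units; within the scatter) in this assay that is not expected to exceed the scatter. Compound 4 is estimated at 5000 nM, between 2000 nM and 14000 nM.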

Compound 4, concentration for 50% growth inhibition: 8980 nM
Compound 4: middle estimate off by 1.8-fold (0.25 log units), on the low side; measured number inside the range.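

Within the data shown here, for the first time, the carbonyl substituent changes alone while the ethenyl chain stays in place, and the step is a 1.9-fold higher number from compound 2 to compound 4 (0.28 log units; within the scatter). On a carbonyl carbon whose other neighbours are a double-bonded chain carbon, methoxy with 2 heavy atoms and morpholin-4-yl with 6 heavy atoms and a six-membered non-aromatic ring therefore cannot be told apart in this assay. Compound 4 also gives a full number, so the full numbers and the limits now split evenly: the limit of > 10000 nM in this assay, at which 2 of the 4 values shown sit.

The compounds shown leave open how a carboxylic acid or an open-chain amine amide would read on the ethenyl chain. Among these compounds, they also leave open how the methyl ester would read on the saturated chain, since no measured pair changes the chain alone.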